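The Methoxyphenyl Analogue of Compound 2, Judged from Neighbours

The source may hold more compounds than are shown below. What is called first, only, known or untested is meant among the compounds shown, and "the series" means these compounds.

Measured compounds:
compound 1 `Cc1ccc(Cn2cc(COc3ccc4c(=O)ccoc4c3)nn2)cc1` — > 100000 nM
compound 2 `O=c1ccoc2cc(OCc3cn(Cc4cccc(F)c4)nn3)ccc12` — > 100000 nM
compound 3 `O=c1ccoc2cc(OCc3cn(Cc4ccccc4F)nn3)ccc12` — 29800 nM

In a functional assay on MDA-MB-231 cells (Homo sapiens) for cytotoxicity, read by MTT assay, with a stated time of 48 h (a higher number here means a weaker inhibitor, a lower number a stronger inhibitor), compound 2 gives > 100000 nM, which is a limit of the assay and not a number. Compound 1 also returns only a limit in this assay, > 100000 nM. Compounds 1 and 2 together make up (the limit of > 100000 nM in this assay, at which 2 of the 3 values shown sit). Going by the values given here, compound 3 is the one member of the set with a number, giving 29800 nM in this assay.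

Compound 4 `COc1ccc(Cn2cc(COc3ccc4c(=O)ccoc4c3)nn2)cc1` differs from compound 2 in a single place: 4-methoxyphenyl in place of 3-fluorophenyl on a saturated chain carbon bound to an aromatic nitrogen.

Among the compounds with values here, two measured steps touch the same position. The step of an at least 3.3-fold lower number from compound 2 to compound 3 (0.52 log units; beyond the scatter) shows that moving the fluorine changes the reading, while the step that the two limits leave unreadable from compound 1 to compound 2 cannot be sized because both ends sit at the limit. Within the data shown here, no measured step puts a methoxy group on the ring, so the change from compound 2 to compound 4 has no direct precedent. Among the measured compounds shown here, the only other compound bearing a group in the 4-position, compound 1, sits at the limit.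

Compound 4 is therefore expected to stay at the limit, with the step of a number no higher from compound 2 to compound 4 (the limit leaves the size open) judged to be no change beyond the scatter. The estimate for compound 4 in this assay is 100000 nM, with a range from 40000 nM to 300000 nM.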

Compound 4, half-maximal inhibitory concentration: > 100000 nM
Compound 4 was reported as a limit; the forecaster's own chance of this, stated with the estimate: 70%; the middle value lies on the limit itself.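

In this assay the 4-methoxyphenyl group of compound 4 gives a limit, as do the 4-methylphenyl group of compound 1 and the 3-fluorophenyl group of compound 2, so a group bringing a hydrogen-bond acceptor has not moved the reading off that limit: the limit of > 100000 nM in this assay, at which 3 of the 4 values shown sit. Against the one measured number, 4-methoxyphenyl in place of 2-fluorophenyl gives an at least 3.3-fold higher number from compound 3 to compound 4 (0.52 log units; beyond the scatter), which leaves compound 3 as the only compound shown with a number for a group on a saturated chain carbon bound to an aromatic nitrogen. The steps among compound 1, compound 2 and compound 4 cannot be read, as both ends of each are limits.

From the compounds shown here alone, whether these three compounds differ from one another at all stays open, and so does whether the number of compound 3 belongs to 2-fluorophenyl alone. The compounds shown also leave open how the reading would respond to a chlorine atom in place of the fluorine of compound 3, to an amine on the ring, or to a longer chain carrying the ring.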